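A few compounds are considered here, and "the series" means these few. Any claim that something is new, unique, unknown or untested is made for them only; others in the source may bear on it.

Measured compounds in an assay on liver for inhibition of sterol O-acyltransferase 1 (Rattus norvegicus), using microsomes; a higher number here means a weaker inhibitor, a lower number a stronger inhibitor:
compound 1 `CC(C)c1cccc(C(C)C)c1NC(=O)NS(=O)(=O)N1CCCCC1` gives 17000 nM
compound 2 `CCCCCCOS(=O)(=O)NC(=O)Nc1c(C(C)C)cccc1C(C)C` gives 27000 nM
compound 3 `CC(C)c1cccc(C(C)C)c1OC(=O)NS(=O)(=O)N1CCCC1` gives 53000 nM

Compound 3 carries the highest of the three numbers in this assay. Its gap to compound 2 lies within the scatter, and only its gap to compound 1 lies beyond it, so it is not separated from compound 2 on these data.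

Compound 4 `CC(C)c1cccc(C(C)C)c1OC(=O)NS(=O)(=O)N1CCc2ccccc21` differs from compound 3 in one place: 2,3-dihydro-1H-indol-1-yl in place of pyrrolidin-1-yl on a sulfonyl sulfur. For the measured compounds named here, no measured step exchanges one cyclic amine for another on the sulfonyl sulfur. Going by the values given here, the one step that touches this position, a 1.6-fold higher number from compound 1 to compound 2 (0.20 log units; within the scatter), swaps the sulfonyl substituent and stays within the scatter, which gives no direction to expect here. The change from pyrrolidin-1-yl to 2,3-dihydro-1H-indol-1-yl is larger in scope, so the number is estimated to stay close to that of compound 3, with a broad range in both directions.

Compound 4 is expected to give 40000 nM in this assay, between 12000 nM and 130000 nM, the step of a 1.3-fold lower number from compound 3 to compound 4 (0.12 log units; within the scatter) being no more than the scatter allows.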

Compound 4, half-maximal inhibitory concentration: 43000 nM
Compound 4: the middle estimate sits 1.1-fold (0.03 log units) below what was measured, within the range that was stated.
By their numbers in this assay, from the lowest: compounds 1, 2, 4 and 3 (each within the scatter of the next, the first and the last beyond it).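

In this assay, for the compounds shown here, the exchange of pyrrolidin-1-yl for 2,3-dihydro-1H-indol-1-yl on the sulfonyl sulfur gives a 1.2-fold lower number from compound 3 to compound 4 (0.09 log units; within the scatter) and is the first step between two cyclic amines at this position. Adding one six-membered aromatic ring of carbon only, with 9 heavy atoms entering where 5 leave, produces no readable change in the number, so this position shows no sensitivity to this particular enlargement. No measurement here bears on why the number holds.

Open, from the compounds shown here alone, is whether a carboxylic acid or a primary amine in place of the cyclic amine on the sulfonyl sulfur would move the number beyond the scatter. Also open, going by these compounds, is how an open-chain group such as diethylamino would compare; compound 1 and compound 3 differ in more than one place and do not settle this.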